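The source may report more compounds than this note shows. Statements on the series, on what has been measured and on what is new or still open speak of the compounds shown alone.

Measured compounds and their maximal responses in a functional assay on CHO cells for agonist activity at Melanocortin receptor 4 (Homo sapiens), read by cAMP accumulation; on this read-out lower numbers stand for smaller maximal responses and higher numbers for larger maximal responses:

compound 1 `CC[C@H](NC(C)=O)c1cc(Cl)ccc1C1CCN(C(=O)[C@H]2CN(C(C)(C)C)C[C@@H]2c2ccc(F)cc2F)CC1` — compound 1 gives 83%
compound 2 `CC[C@H](NC(C)=O)c1cc(Cl)ccc1C1CCN(C(=O)[C@@H]2CN(C(C)(C)C)C[C@H]2c2ccc(Cl)cc2Cl)CC1` — compound 2 gives 48%

Compound 2 stands lowest of the two numbers in this assay; the nearest is compound 1, whose value lies higher by a gap beyond the usual scatter. For the measured compounds named here, the two compounds share the same core and differ only in the aryl group on the saturated ring carbon, but no step between them has been worked out, so only their two values are known.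

The next compound, compound 3 `CC[C@H](NC(C)=O)c1cc(Cl)ccc1C1CCN(C(=O)[C@@H]2CN(C(C)(C)C)C[C@H]2c2ccc(C(F)(F)F)cc2F)CC1`, carries 2-fluoro-4-(trifluoromethyl)phenyl in place of 2,4-dichlorophenyl on a saturated ring carbon. The aryl group that enters keeps one fluorine atom in common with the group of compound 1 and brings a trifluoromethyl in place of the second halogen.

Going by the values given here, with no computed step available, the change in this assay is expected to be a moderate rise, of a size comparable to or somewhat smaller than the gap between compound 2 and compound 1. The expected step is a number 17 percentage points higher from compound 2 to compound 3 (beyond the scatter). Compound 3 is thus estimated at 65%, with a range from 40% to 90%.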

Compound 3, largest response reached (reported as percent of maximum), in percent of the reference or control that the assay uses: 99%
For compound 3 the middle estimate is 34 percentage points below the measured one, and the stated range ends below it.
By their numbers in this assay, from the lowest: compound 2; then compound 1; then compound 3.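

On the saturated ring carbon of the five-membered non-aromatic ring, the aryl group strongly controls the maximal response in this assay: 2-fluoro-4-(trifluoromethyl)phenyl in place of 2,4-dichlorophenyl gives a number 51 percentage points higher from compound 2 to compound 3 (beyond the scatter). For the compounds shown here, this is the first single-place step, and it shows that the maximal response is not set by the shared core alone; neither aryl group carries a hydrogen-bond donor, a hydrogen-bond acceptor or a net charge, so the step comes with those counts unchanged. Nothing available here bears on the reason for this rise.

Going by these compounds alone, the swap alters both halogen substituents at once, so these compounds do not separate the contribution of the fluorine from that of the trifluoromethyl, and compound 1 has no single-place step to either of the other two compounds. From the compounds shown here alone, how a nitrile or a methoxy group in place of the trifluoromethyl would read in this assay stays open, as does whether the higher maximal response of compound 3 is accompanied by any change in potency.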